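Halogen swap on the aryl ketone of compound 1

A few compounds are considered here, and "the series" means these few. Any claim that something is new, unique, unknown or untested is made for them only; others in the source may bear on it.

Measured compounds:
- compound 1 `COc1cc(-c2cc(/C=C/C(=O)c3ccc(Cl)c(Cl)c3)[nH]n2)cc(OC)c1OC`: 2%
- compound 2 `COc1ccc(-c2cc(/C=C/C(=O)c3cc(OC)c(OC)c(OC)c3)[nH]n2)cc1OC`: -71%

Both compounds share one core and differ in the aryl group on the carbonyl and in the substitution of the aryl on the pyrazole. In a functional assay on MDA-MB-231 cells (Homo sapiens) for cytotoxicity, read by sulforhodamine B assay, with a stated time of 48 h, tested at 100 uM (a lower number here means a stronger effect, a higher number a weaker effect of the compound at the concentration tested), compound 1 gives 2%, the highest of the two numbers; compound 2 sits far lower, beyond the scatter, so on these two numbers compound 1 is the weaker one.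

Compound 3 `COc1cc(-c2cc(/C=C/C(=O)c3ccc(F)c(F)c3)[nH]n2)cc(OC)c1OC` is not yet measured. Going by the values given here, its single change from compound 1 is 3,4-difluorophenyl in place of 3,4-dichlorophenyl on a carbonyl carbon. Among the compounds with values here, no measured pair shows this kind of exchange, so its effect has to be guessed. The expectation is a small step from compound 1 to compound 3 in this assay, of size a number 8 percentage points higher from compound 1 to compound 3 (within the scatter), which may well stay within the scatter. Compound 3 is therefore estimated at 10%, with a range from -20% to 40%.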

Compound 3, a percentage reported as activity, at one concentration (the size of the read-out at that concentration, not a potency): -49%
For compound 3 the middle estimate is 59 percentage points above the measured one, outside the stated range (below it).
By their numbers in this assay, from the lowest: compound 2; then compound 3; then compound 1.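

In this assay the aryl group on a carbonyl carbon is a sensitive place in this series: 3,4-difluorophenyl in place of 3,4-dichlorophenyl gives a number 51 percentage points lower from compound 1 to compound 3 (beyond the scatter), a large step with the rest of compound 1 unchanged. Going by these compounds alone, this is the first exchange in the set confined to one place, and it shows that changing only the halogen on this aryl group moves the read-out beyond the scatter, although both groups have the same number of heavy atoms. No available measurement accounts for the step.

Open, on these data alone, is how the read-out responds to other groups at this place, such as unsubstituted phenyl, 3,4-dibromophenyl or a phenyl carrying a carboxylic acid. Also open, as far as these compounds go, is whether this exchange gives a similar step when the other aryl group on the shared core is changed.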